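A few compounds are considered here, and "the series" means these few. Any claim that something is new, unique, unknown or untested is made for them only; others in the source may bear on it.

Measured so far:
compound 1 `O=C(Nc1ccc(Oc2ccnc3[nH]ccc23)cc1)c1cn(-c2ccc(F)cc2)c2ccccc2c1=O` — 720 nM in a functional assay on MCF7 cells (Homo sapiens) for inhibition, read by MTT assay, with a stated time of 72 h; on this read-out lower numbers stand for stronger inhibition and higher numbers for weaker inhibition
compound 2 `O=C(Nc1ccc(Oc2ccnc3[nH]ccc23)cc1)c1cn(-c2ccc(C(F)(F)F)cc2Cl)c2ccccc2c1=O` — 3570 nM in this assay

Compound 2 gives the highest of the two numbers in this assay; compound 1 is the nearer one. Among the measured compounds shown here, the only measured step, a 5.0-fold higher number from compound 1 to compound 2 (0.70 log units; beyond the scatter), bears directly on the change to compound 3 `COc1ccc(-n2cc(C(=O)Nc3ccc(Oc4ccnc5[nH]ccc45)cc3)c(=O)c3ccccc32)cc1`: 4-methoxyphenyl in place of 2-chloro-4-(trifluoromethyl)phenyl on an aromatic nitrogen. That step went with a singly substituted phenyl on the aromatic nitrogen becoming a doubly substituted one; compound 3 returns to a singly substituted phenyl, so a move back toward compound 1 is expected. Compound 3 is estimated at 900 nM, range 350 nM to 2500 nM. The expected step is a 4.0-fold lower number from compound 2 to compound 3 (0.60 log units; beyond the scatter), beyond the scatter.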

Compound 3, half-maximal inhibitory concentration: 4650 nM
Beside the measured number, compound 3's estimate is 5.2-fold (0.71 log units) below it; measured number above the stated range.
By their numbers in this assay, from the lowest: compound 1; then compounds 2 and 3 (each within the scatter of the next).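

In this assay, a single substituent on the phenyl does not by itself restore the level of compound 1: methoxy in place of fluoro gives a 6.5-fold higher number from compound 1 to compound 3 (0.81 log units; beyond the scatter) on the aromatic nitrogen's phenyl. The swap of 2-chloro-4-(trifluoromethyl)phenyl for 4-methoxyphenyl gives a 1.3-fold higher number from compound 2 to compound 3 (0.11 log units; within the scatter), so these two groups cannot be told apart here, and substituent count alone does not track the numbers across compounds 1, 2 and 3. No measurement at hand explains the standing of the 4-fluorophenyl group.

Open, as far as these compounds go, is whether a plain phenyl, a 4-chlorophenyl or a short alkyl chain on that nitrogen would group with compound 1 or with compounds 2 and 3.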